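A few compounds are considered here, and "the series" means these few. Any claim that something is new, unique, unknown or untested is made for them only; others in the source may bear on it.

Of the compounds shown here, two with a shared core have been tested in an assay for inhibition of LL-diaminopimelate aminotransferase, chloroplastic (Arabidopsis thaliana); on this read-out lower numbers stand for stronger inhibition and higher numbers for weaker inhibition. Compound 1 `NN1C(=O)/C(=C/c2ccc(Cl)cc2)SC1=S` is reported in this assay as "not active" (no number reported). Compound 2 `CCN1C(=O)/C(=C/c2ccc(OC)cc2)SC1=S` reaches in this assay only a limit of > 200000 nM, so no number for it is known. Where compound 2 stands can therefore be told only through (the limit of > 200000 nM in this assay, at which 1 of the 2 values shown sits), alongside one further entry without a single number. Within the data shown here, no pair of measured compounds differs in just one place, so no measured step is available. Compound 3 `COc1ccc(/C=C2\SC(=S)N(N)C2=O)cc1` has not yet been measured. It differs from compound 2 by amino in place of ethyl on an amide-type nitrogen in a ring. Compound 1 carries the same amino group on its ring nitrogen and shows no activity, and compound 2 with the ethyl group gives only a limit, so nothing among the shown values points toward a gain. The step is expected to be a step that the limit leaves unreadable from compound 2 to compound 3, meaning no change beyond the usual scatter. Compound 3 is therefore estimated at 300000 nM, within a range from 100000 nM to 1000000 nM, and the assay will most likely again report only a limit.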

Compound 3, half-maximal inhibitory concentration: 155000 nM
Beside the measured number, compound 3's estimate is 1.9-fold (0.29 log units) above it, within the range that was stated.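

In this assay, putting amino in place of ethyl on the amide-type nitrogen gives an at least 1.2-fold lower number from compound 2 to compound 3 (0.11 log units; that floor lies within the scatter), so the only size that can be read for this change is a floor inside the usual scatter of repeated measurements, and no real gain can be claimed from it. Even so, the set now holds its first actual number, as compound 3 gives 155000 nM, which shows that an amino group on this nitrogen can coexist with measurable, though very modest, inhibition. The same amino group does not settle the outcome alone, since with chloro on its phenyl ring where compound 3 has methoxy, compound 1 gives "not active" (no number reported).

The true size of the step stays unknown because compound 2 has only a limit and not a number: the limit of > 200000 nM in this assay, at which 1 of the 3 values shown sits. Also open is whether a longer chain such as butyl, or a carboxylic acid, on this same nitrogen would move the number further, since the compounds shown carry only ethyl and amino there.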